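A longer chain and a dimethylated cyanoguanidine on the shared core

This account rests on a few compounds, and the source may have more. Where it says the series, first, only, none or still open, it means among the compounds named here.

Of the compounds shown here, three with the same core have been measured in a functional assay on the whole organism with Rattus norvegicus as the target, at a dose of 100 mg/kg; a higher number here means more inhibition at the dose given (going by the name of the read-out), a lower number less inhibition. Compound 1 `CC/N=C(/NC#N)NCCCCn1nc(-c2ccccc2)ccc1=O` gives 58.8%. Compound 2 `C/N=C(/NC#N)NCCCCCn1nc(-c2ccccc2)ccc1=O` gives 47.6%, which is the second highest of the three numbers: its nearest neighbour is compound 1, as a number 11.2 percentage points lower from compound 1 to compound 2 (beyond the scatter) shows, and its furthest is compound 3 `C/N=C(\S)N(C)CCCCn1nc(-c2ccccc2)ccc1=O`, which gives 17.5%, a drop of a number 30.1 percentage points lower from compound 2 to compound 3 (beyond the scatter). The step of a number 41.3 percentage points lower from compound 1 to compound 3 (beyond the scatter) points the same way.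

Compound 4 `CN(C)/C(=N/CCCCCCn1nc(-c2ccccc2)ccc1=O)NC#N` differs from compound 2 by a group of 9 heavy atoms (5 carbon, 4 nitrogen; no ring) in place of a group of 7 heavy atoms (3 carbon, 4 nitrogen; no ring), on a saturated chain carbon, five bonds along the chain from an aromatic nitrogen. The measured steps bear on it only in part: the modest drop of a number 11.2 percentage points lower from compound 1 to compound 2 (beyond the scatter) came from a rearrangement within the same kind of group and a longer chain, whereas the large drops of a number 30.1 percentage points lower from compound 2 to compound 3 (beyond the scatter) and a number 41.3 percentage points lower from compound 1 to compound 3 (beyond the scatter) came from a change to a sulfur-bearing group, which compound 4 does not have. Compound 4 keeps a cyanoguanidine-type group, so a modest step downward, not a large one, is expected. The estimate for compound 4 in this assay is therefore 40%, in the range 20% to 60%, which is expected to mean a step of a number 7.6 percentage points lower from compound 2 to compound 4 (within the scatter).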

Compound 4, a percentage reported as inhibition, in the whole organism at one dose (the size of the read-out at that dose, not a potency): 58.4%
Compound 4: the middle estimate sits 18.4 percentage points below what was measured, within the range that was stated.
By their numbers in this assay, from the lowest: compound 3; then compound 2; then compounds 4 and 1 (each within the scatter of the next).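

In this assay, the exchange on a saturated chain carbon, five bonds along the chain from an aromatic nitrogen, gives a number 10.8 percentage points higher from compound 2 to compound 4 (beyond the scatter). Within the data shown here, this shows that the group of 9 heavy atoms, with 1 hydrogen-bond donor against 2 in the group it replaces, is compatible with more inhibition at this dose than compound 2 gives, whereas the earlier steps from compound 2 and compound 1 led only downward. Nothing available accounts for this rise.

Compound 2 and compound 4 differ in both chain length and the substitution of the end group, so the compounds shown leave open how much of the step belongs to each. On these data alone, how a longer chain, or a carboxylic acid in place of this group, would read in this assay also remains open.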